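The source may report more compounds than this note shows. Statements on the series, on what has been measured and on what is new or still open speak of the compounds shown alone.

Three compounds share one core and differ only in the group attached to the amide nitrogen through a single saturated chain carbon. Compound 1 `Cc1cc2c(cc1Cc1ccc(C(=O)NCC3CCCCC3)o1)C(C)(C)CCC2(C)C` carries a cyclohexyl group there, compound 2 `Cc1cc2c(cc1Cc1ccc(C(=O)NC[C@H]3CC[C@H](C(=O)O)CC3)o1)C(C)(C)CCC2(C)C` a 4-carboxycyclohexyl group, and compound 3 `Cc1ccc(CNC(=O)c2ccc(Cc3cc4c(cc3C)C(C)(C)CCC4(C)C)o2)cc1` a 4-methylphenyl group. In an assay on isolated protein for binding affinity to Gonadotropin-releasing hormone receptor (Homo sapiens) (on this read-out lower numbers stand for stronger inhibition and higher numbers for weaker inhibition), compound 1 gives 180 nM, compound 2 gives 250 nM and compound 3 gives 83 nM. Compound 2 thus shows the highest number of the three: the gap to compound 1 is small, a 1.4-fold higher number from compound 1 to compound 2 (0.14 log units; within the scatter), while the gap to compound 3 is larger, a 3.0-fold lower number from compound 2 to compound 3 (0.48 log units; beyond the scatter).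

Compound 4 `Cc1cc2c(cc1Cc1ccc(C(=O)NCc3ccccc3)o1)C(C)(C)CCC2(C)C` has not yet been measured. Its difference from compound 2 is phenyl in place of 4-carboxycyclohexyl on a saturated chain carbon bound to an amide-type nitrogen. Among the measured compounds shown here, two measured steps bear on this change. Replacing the cyclohexyl group of compound 1 by a flat aromatic ring gave a 2.2-fold lower number from compound 1 to compound 3 (0.34 log units; beyond the scatter), and the same kind of exchange from the carboxy-bearing ring gave a 3.0-fold lower number from compound 2 to compound 3 (0.48 log units; beyond the scatter). The change to compound 4 likewise trades a saturated carboxy-bearing ring for an aromatic ring, so a modest fall in the number is expected in this assay, of roughly the size seen for compound 3, expressed as a 2.3-fold lower number from compound 2 to compound 4 (0.36 log units; beyond the scatter). For compound 4 the expected value is therefore 110 nM, with a likely range from 40 nM to 300 nM.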

Compound 4, inhibition constant: 102 nM
Estimate against measurement, compound 4: 1.1-fold (0.03 log units) above; the measured number falls inside the stated range.
By their numbers in this assay, from the lowest: compounds 3, 4, 1 and 2 (each within the scatter of the next, the first and the last beyond it).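

Phenyl in place of 4-carboxycyclohexyl gives a 2.5-fold lower number from compound 2 to compound 4 (0.39 log units; beyond the scatter), so a plain aromatic ring at this position again separates from the carboxy-bearing saturated ring, and it does so without the methyl group of compound 3. Phenyl in place of cyclohexyl gives a 1.8-fold lower number from compound 1 to compound 4 (0.25 log units; within the scatter), and hydrogen in place of methyl on an aromatic carbon gives a 1.2-fold higher number from compound 3 to compound 4 (0.09 log units; within the scatter); neither step can be told from repeat-measurement noise, so the methyl group has no readable effect here, and an advantage of aromatic over cyclohexyl now rests only on the step from compound 1 to compound 3, not on this unsubstituted pair. No independent measurement accompanies these compounds to explain any of these steps.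

The carboxylic acid appears only on the saturated ring, so these compounds cannot show whether a carboxylic acid on the phenyl ring would carry the same penalty or none. From the compounds shown here alone, how an amine on either ring, or a longer chain between the amide nitrogen and the ring, would read at this position also remains open.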